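Swapping a cyanophenyl for methylphenyl: expected cytotoxicity

The source may hold more compounds than are shown below. What is called first, only, known or untested is meant among the compounds shown, and "the series" means these compounds.

This study concerns four close relatives sharing one core, tested in a toxicity assay on NIH3T3 cells (Mus musculus) for cytotoxicity, read by resazurin assay; a higher number here means that more compound is needed for the effect, a lower number that less compound is needed. Compound 1 `COC(=O)c1ccc(NCc2cncn2Cc2ccc([N+](=O)[O-])cc2)cc1-c1ccccc1` gives > 10000 nM, which is a limit of the assay and not a number. Compound 2 `COC(=O)c1ccc(NCc2cncn2Cc2cccc(N)c2)cc1-c1ccccc1` likewise gives only a limit, > 10000 nM. For the measured compounds named here, compound 3 `COC(=O)c1ccc(NCc2cncn2Cc2ccccc2C#N)cc1-c1ccccc1` is the single member with a measured number, giving 25000 nM in this assay. It stands as the only number shown among the three. The steps between the measured compounds, a step that the two limits leave unreadable from compound 1 to compound 2, a step that the limit leaves unreadable from compound 1 to compound 3 and a step that the limit leaves unreadable from compound 2 to compound 3, cannot be sized because two of the three values sit at the limit of > 10000 nM in this assay, at which 2 of the 3 values shown sit.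

Compound 4 `COC(=O)c1ccc(NCc2cncn2Cc2ccc(C)cc2)cc1-c1ccccc1` differs from compound 3 by 4-methylphenyl in place of 2-cyanophenyl on a saturated chain carbon bound to an aromatic nitrogen. Going by the values given here, none of the measured steps involves a 4-methylphenyl group, and none of them is readable, so they give neither a size nor a direction. Compound 3 itself lies near the limit of the assay, and the two other compounds sit at it. For compound 4 the expected step in this assay is therefore a 1.3-fold lower number from compound 3 to compound 4 (0.10 log units; within the scatter), within the scatter. The estimate for compound 4 is 20000 nM, between 8000 nM and 60000 nM, with a fair chance that only a limit is reported.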

Compound 4, half-maximal effective concentration: 50000 nM
The estimate for compound 4 lay 2.5-fold (0.40 log units) below the measured number; the range from low to high includes it.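

In this assay, 4-methylphenyl in place of 2-cyanophenyl on a saturated chain carbon bound to an aromatic nitrogen gives a 2.0-fold higher number from compound 3 to compound 4 (0.30 log units; within the scatter). For the compounds shown here, this is the first readable step, and it shows that trading a group with a triple bond and a hydrogen-bond acceptor for one with neither does not move the number beyond the usual scatter. The other steps to compound 4 cannot be read because the values on their far side are limits, not numbers: the limit of > 10000 nM in this assay, at which 2 of the 4 values shown sit.

Going by these compounds alone, the single readable step changes both the group on the ring and where it sits, so 2-methylphenyl or 4-cyanophenyl would be needed to tell these two changes apart. From the compounds shown here alone, it also remains open whether any group at this position can bring the number beyond the scatter, for example a phenyl ring carrying a carboxylic acid, or a longer chain between the ring and the aromatic nitrogen.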